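A few compounds are considered here, and "the series" means these few. Any claim that something is new, unique, unknown or untested is made for them only; others in the source may bear on it.

Measured compounds in an assay for inhibition of Fatty-acid amide hydrolase 1 (Rattus norvegicus); on this read-out higher numbers stand for weaker inhibition and lower numbers for stronger inhibition:
compound 1 `O=C(O)c1cc(-c2cnc(C(=O)CCc3ccc(-c4ccccc4)cc3)o2)ccn1` gives 50 nM
compound 2 `NC(=O)c1cccc(-c2cnc(C(=O)CCc3ccc(-c4ccccc4)cc3)o2)n1` gives 1.2 nM
compound 3 `COC(=O)c1cccc(-c2cnc(C(=O)CCc3ccc(-c4ccccc4)cc3)o2)n1` gives 1.2 nM

Compound 3 stands level with compound 2 at the digits shown, the two together giving the lowest numbers of the three; its nearest neighbour is compound 2 with no change at the digits printed from compound 2 to compound 3 (within the scatter), and its furthest is compound 1 with a 42-fold lower number from compound 1 to compound 3 (1.62 log units; beyond the scatter).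

Compound 4 `O=C(CCc1ccc(-c2ccccc2)cc1)c1ncc(-c2cccnc2)o1` differs from compound 3 by pyridin-3-yl in place of 6-(methoxycarbonyl)pyridin-2-yl on an aromatic carbon. Within the data shown here, of the measured steps, no change at the digits printed from compound 2 to compound 3 (within the scatter) shows that swapping the methoxy for an amino on the carbonyl carbon leaves the number unchanged, but no measured pair removes the carbonyl substituent altogether, and a 42-fold lower number from compound 1 to compound 2 (1.62 log units; beyond the scatter) and a 42-fold lower number from compound 1 to compound 3 (1.62 log units; beyond the scatter) each change two things at once, so neither isolates the loss of that group. The change is therefore only loosely anchored; a rise in the number beyond the scatter is expected in this assay, of moderate size, a 13-fold higher number from compound 3 to compound 4 (1.10 log units; beyond the scatter). Compound 4 is thus estimated at 15 nM, with a range from 4 nM to 60 nM.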

Compound 4, inhibition constant: 1.1 nM
Compound 4: the middle estimate sits 14-fold (1.13 log units) above what was measured; measured number outside the range, below it.
By their numbers in this assay, from the lowest: compounds 4, 2 and 3 (each within the scatter of the next); then compound 1.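

In this assay, putting the smaller pyridin-3-yl on the aromatic carbon next to the ring oxygen gives a 1.1-fold lower number from compound 3 to compound 4 (0.04 log units; within the scatter), and the comparison with the amide gives a 1.1-fold lower number from compound 2 to compound 4 (0.04 log units; within the scatter), so at this position neither the methoxycarbonyl nor the carbamoyl group is needed to reach this level. The only large gap among the four remains with the 2-carboxypyridin-4-yl group, at a 45-fold lower number from compound 1 to compound 4 (1.66 log units; beyond the scatter), and compound 4 shows that a pyridine ring without any carbonyl substituent falls on the side of the ester and the amide. Nothing at hand explains why these groups make so little difference here.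

As far as these compounds go, what a plain phenyl ring would give at this carbon remains open. So does whether the gap of compound 1 follows the carboxylic acid itself or its place on the pyridine ring, which a carboxylic acid on a pyridin-2-yl ring would help to separate.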